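Oxygen-linked ring swap on the shared core

The source may hold more compounds than are shown below. What is called first, only, known or untested is meant among the compounds shown, and "the series" means these compounds.

Measured so far:
compound 1 `CC(C)N1CC[C@H](NC(=O)c2cc(-c3ccc(NS(=O)(=O)c4cccc(Cl)c4Cl)cc3)nc3[nH]ncc23)C1`: 4 nM
compound 2 `O=C(NC1CCN(CC2CC2)C1)c1cc(-c2ccc(NS(=O)(=O)c3cccc(Cl)c3Cl)cc2)nc2[nH]ncc12`: 1 nM
compound 3 `Cc1n[nH]c2nc(-c3ccc(NS(=O)(=O)c4cc(Cl)ccc4F)cc3)nc(OC3CCOCC3)c12`: 5 nM

In an assay for inhibition of serine/threonine-protein kinase Sgk1 (Homo sapiens), with stated times of 30 min and 60 min, in the presence of a further agent that is not named here (on this read-out lower numbers stand for stronger inhibition and higher numbers for weaker inhibition), compound 3 gives the highest of the three numbers; compound 1 sits within the scatter of it, while compound 2 lies beyond the scatter below it. Within the data shown here, the only measured step, a 4.0-fold lower number from compound 1 to compound 2 (0.60 log units; beyond the scatter), concerns a saturated ring on an amide-type nitrogen and is modest in size.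

Compound 4 `CCN1CCCC(Oc2nc(-c3ccc(NS(=O)(=O)c4cc(Cl)ccc4F)cc3)nc3[nH]nc(C)c23)C1` differs from compound 3 by 1-ethylpiperidin-3-yl in place of oxan-4-yl on an oxygen on an aromatic ring. Among the measured compounds shown here, no measured pair shows this change at this oxygen, so the step from compound 1 to compound 2 bears on it only loosely: it shows that altering the substituent on a saturated amine-bearing ring in this part of the molecule moved the number by a modest amount, and the values of compound 1 and compound 2 show that such rings are compatible with low numbers here. The step is therefore expected to be small, a 1.7-fold lower number from compound 3 to compound 4 (0.22 log units; within the scatter), with a slight lowering as the more likely direction. Compound 4 is expected to give about 3 nM in this assay, in the range 1 nM to 10 nM.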

Compound 4, half-maximal inhibitory concentration: 6 nM
Compound 4: the middle estimate sits 2.0-fold (0.30 log units) below what was measured; the measured number falls inside the stated range.
By their numbers in this assay, from the lowest: compound 2; then compounds 1, 3 and 4 (each within the scatter of the next).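

In this assay the change at the oxygen on an aromatic ring gives a 1.2-fold higher number from compound 3 to compound 4 (0.08 log units; within the scatter) and stays within the scatter, so oxan-4-yl and 1-ethylpiperidin-3-yl cannot be told apart at this position. The earlier compounds shown here carried a saturated ring with an amine nitrogen only on an amide-type nitrogen, whereas compound 4 shows such a ring on this oxygen with a value in the same low range. No measurement bearing on either ring accompanies these values, and the data offer no explanation for the result.

Open, going by these compounds, is whether the ethyl group of 1-ethylpiperidin-3-yl on this oxygen can give way to a hydrogen or a longer chain such as 2-hydroxyethyl. Also open, on these data alone, is whether a ring-free chain such as 2-(dimethylamino)ethyl or a small methyl ether at the same oxygen stays in this range.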